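One ring exchanged on compound 1, and what may follow

This account rests on a few compounds, and the source may have more. Where it says the series, first, only, none or still open, it means among the compounds named here.

Measured compounds:
compound 1 `Cc1ccc2c(c1)/C(=N/NC(=S)N/N=C/c1ccccn1)C(=O)N2`: 3150 nM
compound 2 `Cc1ccc2c(c1)/C(=N/NC(=S)N/N=C/c1ccc(-c3ccccc3)cc1)C(=O)N2`: > 50000 nM (a limit of the assay)
compound 3 `Cc1ccc(O)c(/C=N/NC(=S)N/N=C2\C(=O)Nc3ccc(Br)cc32)c1`: > 50000 nM (a limit of the assay)

In a functional assay on HeLa cells (Homo sapiens) for inhibition, read by MTT assay (on this read-out higher numbers stand for weaker inhibition and lower numbers for stronger inhibition), compound 1 gives 3150 nM, and this is the only result that is a number rather than a limit. Compound 2 reaches only > 50000 nM, which is a limit of the assay and not a measured number. Compound 3 likewise stops at > 50000 nM, again a limit. Compound 1 therefore stands alone, while (the limit of > 50000 nM in this assay, at which 2 of the 3 values shown sit).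

Compound 4 `Cc1ccc2c(c1)/C(=N/NC(=S)N/N=C/c1c(Cl)cccc1Cl)C(=O)N2` has not yet been measured. It differs from compound 1 in one place: 2,6-dichlorophenyl in place of pyridin-2-yl on a carbon with a double bond to nitrogen. For the measured compounds named here, no measured pair of compounds differing in a single place is available, so the size of this step can only be guessed. The expectation is a weakening of inhibition in this assay that goes beyond the usual scatter, so that compound 4 is expected to give 15000 nM, with a likely range from 4000 nM to 50000 nM. The estimated step of a 4.8-fold higher number from compound 1 to compound 4 (0.68 log units; beyond the scatter) would thus be a loss, and a limit rather than a number is a real possibility.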

Compound 4, half-maximal inhibitory concentration: 1790 nM
Beside the measured number, compound 4's estimate is 8.4-fold (0.92 log units) above it, and the stated range ends above it.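

In this assay, exchanging pyridin-2-yl for 2,6-dichlorophenyl gives a 1.8-fold lower number from compound 1 to compound 4 (0.25 log units; within the scatter), so the two compounds cannot be told apart. For the compounds shown here, this is the first readable step at this place, a carbon with a double bond to nitrogen, and it shows that the ring can lose its nitrogen, the one hydrogen-bond acceptor counted in pyridin-2-yl, and gain two chlorine atoms without a change beyond the scatter. Nothing shown explains why these two rings give such similar results.

From the compounds shown here alone, it remains open whether plain phenyl, or a phenyl ring carrying a single chlorine, an amine or a carboxylic acid, would behave in the same way on this carbon. Going by these compounds, it is also open whether 2,6-dichlorophenyl would be tolerated as well on a core other than that of compound 1.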